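Swapping the aryl urea terminus on a triazolyl-pyridine ether

This account rests on a few compounds, and the source may have more. Where it says the series, first, only, none or still open, it means among the compounds named here.

Measured so far:
compound 2, `CN(C)CCCn1cnnc1-c1cc(Oc2ccc(NC(=O)Nc3ccccc3C(F)(F)F)cc2F)ccn1`: 40500 nM
compound 1, `CN(C)CCn1cnnc1-c1cc(Oc2ccc(NC(=O)Nc3ccc(Cl)cc3Cl)cc2F)ccn1`: 7960 nM

In a functional assay on MDA-MB-231 cells (Homo sapiens) for antiproliferative activity, read by MTT assay, with a stated time of 72 h (on this read-out higher numbers stand for weaker inhibition and lower numbers for stronger inhibition), compound 2 stands at the highest of the two numbers recorded, and its nearest neighbour is compound 1, which differs from it in two places. Compound 3, `CN(C)CCCn1cnnc1-c1cc(Oc2ccc(NC(=O)Nc3ccc(Cl)cc3Cl)cc2F)ccn1`, has not been measured. It differs from compound 2 in one place: 2,4-dichlorophenyl in place of 2-(trifluoromethyl)phenyl on an amide-type nitrogen. Because compound 1, which carries the same 2,4-dichlorophenyl group, gives 7960 nM, the step of a 4.1-fold lower number from compound 2 to compound 3 (0.61 log units; beyond the scatter) is expected to run downward, toward stronger inhibition, and to reach beyond the scatter. Compound 3 is therefore estimated at 10000 nM, within a range of 3000 nM to 30000 nM.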

Compound 3, half-maximal inhibitory concentration: 7490 nM
For compound 3 the middle estimate is 1.3-fold (0.13 log units) above the measured one, and the stated range covers the measured number.
By their numbers in this assay, from the lowest: compounds 3 and 1 (each within the scatter of the next); then compound 2.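

In this assay, 2,4-dichlorophenyl in place of 2-(trifluoromethyl)phenyl on an amide-type nitrogen gives a 5.4-fold lower number from compound 2 to compound 3 (0.73 log units; beyond the scatter), so this one change alone moves the number beyond the scatter. By contrast, (dimethylamino)methyl in place of dimethylamino gives a 1.1-fold lower number from compound 1 to compound 3 (0.03 log units; within the scatter), which lies within the scatter, so this chain change leaves the number unresolved from compound 1. Nothing available here accounts for either result.

On these data alone, it remains open whether an unsubstituted phenyl or a 4-chlorophenyl on that nitrogen would match 2,4-dichlorophenyl. As far as these compounds go, it also remains open whether morpholine in place of dimethylamino would shift the number.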